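The source may report more compounds than this note shows. Statements on the series, on what has been measured and on what is new or still open speak of the compounds shown alone.

Compound 1 `C=C1C[C@]23C[C@@]1(O)CC[C@@H]2c1cccc(C)c1[C@@H]3Cn1cc(-c2ccc(C)cc2)nn1` was measured in a functional assay on MCF7 cells (Homo sapiens) for cytotoxicity, read by MTT assay, with a stated time of 4 days; on this read-out higher numbers stand for weaker inhibition and lower numbers for stronger inhibition; compound 1 gives > 20000 nM, which is a limit of the assay and not a number. Compound 2 `C=C1C(=O)[C@]23C[C@@]1(O)CC[C@H]2c1ccc(O)c(C)c1[C@@H]3Cn1cc(-c2ccc(Br)cc2)nn1` gives 270 nM in this assay. Compound 3 `C=C1C(=O)[C@]23C[C@@]1(O)CC[C@H]2c1ccc(OS(=O)(=O)c2ccc(C)cc2)c(C)c1[C@@H]3Cn1cc(-c2ccc(Br)cc2)nn1` gives 250 nM in this assay.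

Among the two numbers shown, compound 3 has the lowest, but its nearest neighbour, compound 2, lies within the scatter of it, so the two cannot be told apart; the third value is a limit rather than a number. Among the measured compounds shown here, the only single-point step measured is a 1.1-fold lower number from compound 2 to compound 3 (0.03 log units; within the scatter), a change on an oxygen on an aromatic ring that left the read-out essentially unchanged.

Compound 4 `C=C1C(=O)[C@]23C[C@@]1(O)CC[C@H]2c1ccc(OS(=O)(=O)c2ccc(C)cc2)c(C)c1[C@@H]3Cn1cc(-c2ccc(Cl)cc2)nn1` differs from compound 3 by chloro in place of bromo on an aromatic carbon. For the measured compounds named here, no measured step touches this position: the one measured step changed a different part of the molecule and stayed within the scatter, and compound 1 differs from compound 3 in several places at once, so its limit says nothing specific about this exchange. With nothing pointing either way, the expected step from compound 3 to compound 4 in this assay is a 1.2-fold higher number from compound 3 to compound 4 (0.08 log units; within the scatter), within the scatter. Compound 4 is therefore estimated at 300 nM, with a range from 120 nM to 800 nM.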

Compound 4, half-maximal inhibitory concentration: 1440 nM
Compound 4: the middle estimate sits 4.8-fold (0.68 log units) below what was measured; the measured number lies above the stated range.
By their numbers in this assay, from the lowest: compounds 3 and 2 (each within the scatter of the next); then compound 4. At a limit, above all of these: compound 1.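

In this assay, chloro in place of bromo on the aromatic ring gives a 5.8-fold higher number from compound 3 to compound 4 (0.76 log units; beyond the scatter), so this exchange of one halogen atom for another moves the read-out clearly. The earlier step on the oxygen, a 1.1-fold lower number from compound 2 to compound 3 (0.03 log units; within the scatter), did not do so, which makes this halogen position the only one of the two single-place changes shown where the read-out responds. The two groups match in heavy-atom count, hydrogen-bond donors, hydrogen-bond acceptors and net charge, and nothing measured here accounts for the difference between them.

From the compounds shown here alone, the step is known only for bromo and chloro with (4-methylphenyl)sulfonyl on the oxygen, so it remains open whether the same exchange would give a similar step in compound 2, which has hydrogen on that oxygen. Going by these compounds, it is also open whether fluoro, methoxy, an amine or a carboxylic acid in this position would stay close to compound 3 or fall nearer to compound 4, or move further still.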